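From pyridin-2-yl to ethoxy in the series

The source may report more compounds than this note shows. Statements on the series, on what has been measured and on what is new or still open speak of the compounds shown alone.

Values in a functional assay on A549 cells (Homo sapiens) for inhibition, read by MTT assay, with a stated time of 72 h; on this read-out lower numbers stand for stronger inhibition and higher numbers for weaker inhibition:
- compound 1 `COc1ccc(-c2cc(C(=O)N3CCC4(CC3)CC(=O)c3nn(C(C)(C)C)cc3O4)c3ccccc3n2)cc1OC`: 2030 nM
- compound 2 `CN(C)c1ccc(-c2cc(C(=O)N3CCC4(CC3)CC(=O)c3nn(C(C)(C)C)cc3O4)c3ccccc3n2)cc1`: 1150 nM
- compound 3 `CC(C)(C)n1cc2c(n1)C(=O)CC1(CCN(C(=O)c3cc(-c4ccccn4)nc4ccccc34)CC1)O2`: 7720 nM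

Compound 3 has the highest number of the three, 7720 nM, beyond the scatter from both others. Compound 4 `CCOc1cc(C(=O)N2CCC3(CC2)CC(=O)c2nn(C(C)(C)C)cc2O3)c2ccccc2n1` carries ethoxy in place of pyridin-2-yl on an aromatic carbon, next to the ring nitrogen: ethoxy in place of pyridin-2-yl on an aromatic carbon. The measured steps that bear on it also replace a group on that aromatic carbon: a 3.8-fold higher number from compound 1 to compound 3 (0.58 log units; beyond the scatter) and a 6.7-fold higher number from compound 2 to compound 3 (0.83 log units; beyond the scatter), both modest, while a 1.8-fold lower number from compound 1 to compound 2 (0.25 log units; within the scatter) lies within the scatter. None of them brings in a group without a ring, and the data show no direction for such a change. In this assay the expected change is no step beyond the scatter, estimated as a 1.2-fold lower number from compound 3 to compound 4 (0.07 log units; within the scatter). Compound 4 is estimated at 6500 nM, with an expected range of 2200 nM to 19000 nM.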

Compound 4, half-maximal inhibitory concentration: > 10000 nM
Compound 4: no number, only a limit; the forecaster's own chance of this, stated with the estimate: 10%; middle value at least 1.5-fold (0.18 log units) from the limit.
By their numbers in this assay, from the lowest: compounds 2 and 1 (each within the scatter of the next); then compound 3. At a limit, above all of these: compound 4.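

In this assay compound 4 gives no number, only a limit: the limit of > 10000 nM in this assay, at which 1 of the 4 values shown sits.

Ethoxy, the only group shown without a ring on this aromatic carbon, gives an at least 8.6-fold higher number from compound 2 to compound 4 (0.93 log units; beyond the scatter) and an at least 4.9-fold higher number from compound 1 to compound 4 (0.69 log units; beyond the scatter), both floors beyond the scatter. Against pyridin-2-yl the reading is weaker: an at least 1.2-fold higher number from compound 3 to compound 4 (0.11 log units; that floor lies within the scatter), a floor within the scatter, so compound 3 and compound 4 cannot be ordered.

On these data alone, whether a ring on this carbon is needed remains open. The compounds shown also leave open how a ringless amine or a longer alkoxy chain would read here.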